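Branched alkyl replacement on the imine nitrogen of a cyanoguanidine

The source may report more compounds than this note shows. Statements on the series, on what has been measured and on what is new or still open speak of the compounds shown alone.

Working notes on two measured cyanoguanidines and one proposed analogue. The read-out throughout is a functional assay on the whole organism (blood, strain Wistar-Okamoto) with Rattus norvegicus as the target, with a stated time of 5 days; on this read-out lower numbers stand for an effect already at smaller amounts and higher numbers for an effect only at larger amounts of compound. Compound 1 `N#CNC(=N)Nc1cccnc1` carries the cyanoguanidine directly on the aromatic core with a free terminal amine; in this assay compound 1 gives 50 mg/kg. Compound 2 `CC(C)(C)C/N=C(\NC#N)Nc1ccncc1` puts a neopentyl group on the double-bonded nitrogen and moves the attachment on the aromatic core; in this assay compound 2 gives 5 mg/kg, the lower of the two numbers, and the gap to compound 1 lies beyond the usual scatter of repeated measurements. Compound 2 is therefore the reference point for the next change.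

Compound 3 `CCC(C)(CC)/N=C(\NC#N)Nc1ccncc1` differs from compound 2 by the change (1-ethyl-1-methylpropyl in place of neopentyl on a double-bonded nitrogen). Among the measured compounds shown here, no measured pair in the set isolates this kind of exchange, so its effect cannot be read from the data at hand; the two alkyl groups are of similar size and shape, and the step is expected to stay within the scatter, if anything with no clear direction, so the step from compound 2 to compound 3 is estimated as no change at the digits printed from compound 2 to compound 3 (within the scatter). Compound 3 is thus estimated at 5 mg/kg, with a plausible range from 2 mg/kg to 15 mg/kg.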

Compound 3, minimum effective dose: 0.5 mg/kg
For compound 3 the middle estimate is 10-fold (1.00 log units) above the measured one, outside the stated range (below it).
By their numbers in this assay, from the lowest: compound 3; then compound 2; then compound 1.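

In this assay, 1-ethyl-1-methylpropyl in place of neopentyl on a double-bonded nitrogen gives a 10-fold lower number from compound 2 to compound 3 (1.00 log units; beyond the scatter). Among the compounds shown here, this is the only step confined to one place, and it shows that this position is sensitive to the choice of alkyl group: the two groups share no ring and no hydrogen-bond donors or acceptors, and differ in count only by 6 heavy atoms against 5. Nothing at hand bears on the reason for a step of this size.

With a single pair, the role of the added carbon cannot be separated from that of the changed branching, and an unbranched hexyl chain, a cyclohexyl group or a tert-butyl group on the same nitrogen would each help to tell these apart. Going by these compounds, compound 1 differs from compound 2 both on this nitrogen and in the attachment on the aromatic core, so the separate contribution of each change, and whether the 1-ethyl-1-methylpropyl result carries over to the other attachment, remains open.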